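Shortening the chain and ending it in a vinyl

The compounds below may be only part of what the source reports. "The series", "measured", "known", "first", "only" and "open" are said of these compounds alone.

Compound 1, `CCCCCCCc1cc2cn([C@H]3C[C@H](O)[C@@H](CO)O3)c(=O)nc2o1`, was examined in a functional assay on HEL cells (Homo sapiens) for cytotoxicity, read by microscopy; on this read-out lower numbers stand for higher toxicity in this test and higher numbers for lower toxicity in this test. In this assay compound 1 gives > 50000 nM, which is a limit of the assay rather than a measured number. Compound 2, `CCCCCCCCCCc1cc2cn([C@H]3C[C@H](O)[C@@H](CO)O3)c(=O)nc2o1`, carries a longer chain: propyl in place of hydrogen on a saturated chain carbon, seven bonds along the chain from an aromatic carbon. In this assay compound 2 gives > 50000 nM, again only a limit. The step that the two limits leave unreadable from compound 1 to compound 2 therefore cannot be read in size, and both values sit at the limit of > 50000 nM in this assay, at which 2 of the 2 values shown sit. Compound 3, `C=CCCCCc1cc2cn([C@H]3C[C@H](O)[C@@H](CO)O3)c(=O)nc2o1`, differs from compound 1 by vinyl in place of propyl on a saturated chain carbon, four bonds along the chain from an aromatic carbon. Among the measured compounds shown here, the only measured step, between compound 1 and compound 2, concerns chain length at this part of the molecule and was left unreadable by the two limits, so nothing in the data points to a change beyond the scatter in this assay. The step that the limit leaves unreadable from compound 1 to compound 3 is therefore expected to lie within the scatter. Compound 3 is estimated at 80000 nM, with a range from 30000 nM to 300000 nM, most likely again reported only as a limit.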

Compound 3, minimum cytotoxic concentration: > 200000 nM
Compound 3 was reported as a limit; the forecaster's own chance of this, stated with the estimate: 85%; at least 2.5-fold (0.39 log units) between middle value and limit.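

In this assay compound 3 gives > 200000 nM, again a limit and not a number. Among the compounds shown here, compound 1, compound 2 and compound 3 all stand at limits, so no step among them can be read in size. The compounds shown leave open whether any chain on the shared core gives a measurable value in this assay.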